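This account rests on a few compounds, and the source may have more. Where it says the series, first, only, none or still open, it means among the compounds named here.

In a functional assay on MCF7 cells (Homo sapiens) for antiproliferative activity, read by MTT assay, with a stated time of 24 h (a lower number here means a stronger inhibitor, a higher number a weaker inhibitor), compound 1 `O=S(=O)(c1ccccc1)n1c(-c2cn(-c3ccccc3)nc2-c2ccc(F)cc2)nc2ccccc21` gives 690 nM and compound 2 `Cc1ccc(C)c(S(=O)(=O)n2c(-c3cn(-c4ccccc4)nc3-c3ccc(F)cc3)nc3ccccc32)c1` gives 430 nM, so compound 2 stands level with compound 1 within the scatter. Compound 3 `O=[N+]([O-])c1ccc(S(=O)(=O)n2c(-c3cn(-c4ccccc4)nc3-c3ccc(F)cc3)nc3ccccc32)cc1` has 4-nitrophenyl in place of 2,5-dimethylphenyl on a sulfonyl sulfur. Among the compounds with values here, the only measured step bearing on this place is a 1.6-fold lower number from compound 1 to compound 2 (0.21 log units; within the scatter), which also swaps the aryl group on the sulfonyl sulfur and stays within the scatter. Within the data shown here, no measured compound carries a nitro group, so the guidance is thin. No shift beyond the scatter is expected, and the expected step is a 1.2-fold higher number from compound 2 to compound 3 (0.07 log units; within the scatter). Compound 3 is estimated at 500 nM, with an expected range of 200 nM to 1200 nM.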

Compound 3, half-maximal inhibitory concentration: 1370 nM
For compound 3 the middle estimate is 2.7-fold (0.44 log units) below the measured one, and the stated range ends below it.
By their numbers in this assay, from the lowest: compounds 2, 1 and 3 (each within the scatter of the next, the first and the last beyond it).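

In this assay the aryl group on the sulfonyl sulfur can shift the number beyond the scatter, as 4-nitrophenyl in place of 2,5-dimethylphenyl gives a 3.2-fold higher number from compound 2 to compound 3 (0.50 log units; beyond the scatter) for this change. Nitro in place of hydrogen on an aromatic carbon gives only a 2.0-fold higher number from compound 1 to compound 3 (0.30 log units; within the scatter), so the separation holds against compound 2 and not against compound 1. No evidence on the cause of either step is available. Still open, from the compounds shown here alone, is whether an amine or a carboxylic acid on this aromatic ring would follow nitro or the methyl groups of compound 2.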